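The source may report more compounds than this note shows. Statements on the series, on what has been measured and on what is new or still open speak of the compounds shown alone.

The series shares one core: compound 3 is `CCn1c([C@@H](C)NS(=O)(=O)c2ccccc2)nc2ccc(C(F)(F)F)cc21`, compound 1 is `CCn1c([C@@H](C)NS(=O)(=O)c2ccc(Cl)cc2)nc2cc(C(N)=O)ccc21` and compound 2 is `CCn1c([C@@H](C)NS(=O)(=O)c2ccc(Cl)cc2)nc2ccc(S(C)(=O)=O)cc21`. Within the data shown here, in an ADME assay (liver) for metabolic stability, with Liver microsome (Homo sapiens) as the target, read by LC-MS, using microsomes and NADPH, with a stated time of 5 min, at 37 degrees C (on this read-out higher numbers stand for fast clearance and lower numbers for slow clearance), compound 3 gives 14 mL.min-1.g-1, the only measured number among the three compounds. Compound 1 returns only a limit of the assay, < 5 mL.min-1.g-1. Compound 2 likewise returns only a limit, < 5 mL.min-1.g-1. Among the measured compounds shown here, two of the three results therefore sit at the limit of < 5 mL.min-1.g-1 in this assay, at which 2 of the 3 values shown sit, and compound 3 stands as the one compound whose clearance can be placed on the scale.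

Compound 4, `CCn1c([C@@H](C)NS(=O)(=O)c2cn(C)c(C)n2)nc2ccc(C(F)(F)F)cc21`, is not yet measured in this assay. It differs from compound 3 by 1,2-dimethyl-1H-imidazol-4-yl in place of phenyl on a sulfonyl sulfur. For the measured compounds named here, no measured pair differs in one place, so no step from the data can be used to scale this change. The expectation in this assay is a moderate step toward slower clearance, with a result within the usual scatter also possible. Compound 4 is expected to give about 8 mL.min-1.g-1, between 3 mL.min-1.g-1 and 20 mL.min-1.g-1. The expected step is a 1.8-fold lower number from compound 3 to compound 4 (0.24 log units; within the scatter).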

Compound 4, intrinsic clearance in microsomes: 43 mL.min-1.g-1
Compound 4: the middle estimate sits 5.4-fold (0.73 log units) below what was measured; measured number outside the range, above it.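

In this assay, the group on the sulfonyl sulfur is the only place in the series where a single change can be scaled: 1,2-dimethyl-1H-imidazol-4-yl in place of phenyl gives a 3.1-fold higher number from compound 3 to compound 4 (0.49 log units; beyond the scatter). Clearance therefore responds to the group at this place, and replacing the six-membered ring of carbon only with this five-membered ring with 2 hetero atoms raises the number rather than lowering it. This single pair does not show which part of the entering group carries the step.

As far as these compounds go, whether an unsubstituted imidazole or a pyridine ring at this place would give the same step remains open, as does the separate role of the methyl groups. The results for compound 1 and compound 2 are limits, so no steps to them can be read: the limit of < 5 mL.min-1.g-1 in this assay, at which 2 of the 4 values shown sit.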